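The compounds below may be only part of what the source reports. "The series", "measured", "known", "first", "only" and "open" are said of these compounds alone.

Of the compounds shown here, two built on a shared core have been tested in a functional assay on Ishikawa cells (Homo sapiens) for inhibition, read by MTT assay, with a stated time of 48 h; a higher number here means a weaker inhibitor, a lower number a stronger inhibitor. Compound 1 `CCOC(=O)c1c(N)sc(/N=C/c2ccc([N+](=O)[O-])o2)c1C(=O)OCC` gives 7600 nM. For the measured compounds named here, compound 2 `CCOC(=O)c1c(N)sc(/N=C/c2ccc(Br)cc2)c1C(=O)OCC` gives 46100 nM, the highest of the two numbers, and the only step measured so far, a 6.1-fold higher number from compound 1 to compound 2 (0.78 log units; beyond the scatter), shows that exchanging the aryl group on the carbon with a double bond to nitrogen moves the number by a modest amount. Compound 3 `CCOC(=O)c1c(N)sc(/N=C/c2ccncc2)c1C(=O)OCC` has not yet been measured in this assay. It differs from compound 2 by pyridin-4-yl in place of 4-bromophenyl on a carbon with a double bond to nitrogen. Going by the values given here, no measured step covers this particular exchange; the one step that exists involved a different pair of groups at the same place and shows only that such swaps can be modest. Compound 3 is thus expected to show a 1.2-fold lower number from compound 2 to compound 3 (0.06 log units; within the scatter), a shift that may not pass the scatter. Compound 3 is estimated at 40000 nM, with a range from 12000 nM to 130000 nM.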

Compound 3, half-maximal inhibitory concentration: 119000 nM
Compound 3: the middle estimate sits 3.0-fold (0.47 log units) below what was measured; the range from low to high includes it.
By their numbers in this assay, from the lowest: compound 1; then compound 2; then compound 3.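

In this assay, pyridin-4-yl in place of 4-bromophenyl on a carbon with a double bond to nitrogen gives a 2.6-fold higher number from compound 2 to compound 3 (0.41 log units; beyond the scatter), so exchanging one six-membered aromatic ring for another at this place can move the number past the scatter. With a third group in hand, the full span at this place reaches a 16-fold higher number from compound 1 to compound 3 (1.19 log units; beyond the scatter), which is a large step, with 5-nitrofuran-2-yl in compound 1 at the low end and pyridin-4-yl in compound 3 at the high end. Nothing available explains this order of the three groups.

Still open, from the compounds shown here alone, is how a cyclohexyl ring or a longer alkyl chain would fare at this place, and where a phenyl ring carrying an amine or a carboxylic acid would fall. Going by these compounds, the ethyl esters stay the same in all three compounds, so their part in these numbers remains unknown.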